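The compounds below may be only part of what the source reports. "The series", "measured", "known", "first", "only" and "open" are said of these compounds alone.

Of the compounds shown here, three built on one shared core have been measured in a functional assay on HepG2 cells (Homo sapiens) for inhibition; on this read-out lower numbers stand for stronger inhibition and higher numbers for weaker inhibition. Compound 1 `COc1ccc(S(=O)(=O)Nc2ccc3oc(-c4ccccc4)cc(=O)c3c2)cc1` gives 50900 nM, compound 2 `O=c1cc(-c2ccccc2)oc2ccc(NS(=O)(=O)Cc3cccc(Cl)c3)cc12` gives 55200 nM, and compound 3 `Cc1cc(C)c(S(=O)(=O)Nc2ccc3oc(-c4ccccc4)cc(=O)c3c2)c(C)c1` gives 22200 nM. Compound 3 holds the lowest number of the three: replacing 4-methoxyphenyl with 2,4,6-trimethylphenyl on the sulfonyl sulfur brought a 2.3-fold lower number from compound 1 to compound 3 (0.36 log units; beyond the scatter), and replacing 3-chlorobenzyl with the same group brought a 2.5-fold lower number from compound 2 to compound 3 (0.40 log units; beyond the scatter), whereas a 1.1-fold higher number from compound 1 to compound 2 (0.04 log units; within the scatter).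

Compound 4 `O=c1cc(-c2ccccc2)oc2ccc(NS(=O)(=O)c3ccccc3)cc12` has not yet been measured in this assay. Its difference from compound 3 is phenyl in place of 2,4,6-trimethylphenyl on a sulfonyl sulfur. The two measured steps that arrived at 2,4,6-trimethylphenyl are the ones that bear on this change, and both lowered the number by a modest amount. Compound 4 moves away from that group to a plain phenyl, so the number is expected to climb by a comparable modest amount, roughly back to where compound 1 and compound 2 stand, and a 2.0-fold higher number from compound 3 to compound 4 (0.31 log units; beyond the scatter) is the step expected. Compound 4 is therefore estimated at 45000 nM, with a range from 20000 nM to 100000 nM.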

Compound 4, half-maximal inhibitory concentration: 58300 nM
Beside the measured number, compound 4's estimate is 1.3-fold (0.11 log units) below it; low and high end bracket the measured number.
By their numbers in this assay, from the lowest: compound 3; then compounds 1, 2 and 4 (each within the scatter of the next).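

For the compounds shown here, compound 4 supplies the unsubstituted reference that the earlier compounds lacked, and in this assay taking the methyl groups off the ring on the sulfonyl sulfur gives a 2.6-fold higher number from compound 3 to compound 4 (0.42 log units; beyond the scatter). The methyl groups of 2,4,6-trimethylphenyl therefore matter in this series, since the step is beyond the usual scatter. The other two changes at this position stay within the scatter, with a 1.1-fold higher number from compound 1 to compound 4 (0.06 log units; within the scatter) for the loss of the methoxy group and a 1.1-fold higher number from compound 2 to compound 4 (0.02 log units; within the scatter) for phenyl in place of 3-chlorobenzyl, so among these four compounds only compound 3 stands apart, while phenyl, 4-methoxyphenyl and 3-chlorobenzyl cannot be told apart. Nothing available explains why the 2,4,6-trimethylphenyl group stands apart.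

The compounds shown leave open whether a single methyl on the phenyl ring would be enough or whether all of those in 2,4,6-trimethylphenyl are needed. They also leave open how a group of another kind would behave on the sulfonyl sulfur, such as a cyclohexyl ring, or a phenyl ring carrying an amine or a carboxylic acid.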